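From benzylamino to phenoxy on the sulfonyl sulfur

The compounds below may be only part of what the source reports. "The series", "measured", "known", "first", "only" and "open" are said of these compounds alone.

Measured so far:
Compound 1, `CC1(C)C=C(n2ccccc2=O)c2cc(S(=O)(=O)NCc3ccccc3)ccc2O1`: 525 nM
Compound 2, `CN(c1ccccc1)S(=O)(=O)c1ccc2c(c1)C(n1ccccc1=O)=CC(C)(C)O2`: 1.74 nM
Compound 3, `CC1(C)C=C(n2ccccc2=O)c2cc(S(=O)(=O)c3ccccc3)ccc2O1`: 17.4 nM

All three compounds share one core and differ only in what sits on the sulfonyl sulfur. In a functional assay with Rattus norvegicus as the target (a higher number here means that more compound is needed for the effect, a lower number that less compound is needed), compound 1 gives 525 nM, the highest number of the three, so it needs the most compound for the effect. The other two lie well away from it: a 300-fold lower number from compound 1 to compound 2 (2.48 log units; beyond the scatter), and a 30-fold lower number from compound 1 to compound 3 (1.48 log units; beyond the scatter). Between those two, a 10-fold higher number from compound 2 to compound 3 (1.00 log units; beyond the scatter).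

Compound 4, `CC1(C)C=C(n2ccccc2=O)c2cc(S(=O)(=O)Oc3ccccc3)ccc2O1`, is not yet measured. It differs from compound 1 in one place: phenoxy in place of benzylamino on a sulfonyl sulfur. Like the two measured steps away from compound 1, this change removes the benzylamino group, and phenoxy, like the phenyl of compound 3, carries no hydrogen-bond donor. Both steps from compound 1 that bear on this change were large and in the same direction, so a step to a lower number beyond the scatter is expected in this assay here too, though its size is uncertain; the expected step is a 35-fold lower number from compound 1 to compound 4 (1.54 log units; beyond the scatter). Compound 4 is therefore estimated at 15 nM, with a range from 3 nM to 80 nM.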

Compound 4, half-maximal effective concentration: 2.51 nM
The estimate for compound 4 lay 6.0-fold (0.78 log units) above the measured number; measured number below the stated range.
By their numbers in this assay, from the lowest: compounds 2 and 4 (each within the scatter of the next); then compound 3; then compound 1.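

Measured in this assay the swap to phenoxy gives a 210-fold lower number from compound 1 to compound 4 (2.32 log units; beyond the scatter) and so brings the number down to the low end of this series, while a 1.4-fold higher number from compound 2 to compound 4 (0.16 log units; within the scatter) means that phenoxy and methyl(phenyl)amino cannot be told apart on this sulfonyl sulfur. Phenoxy also differs from plain phenyl, with a 6.9-fold lower number from compound 3 to compound 4 (0.84 log units; beyond the scatter) and this shows that losing the hydrogen-bond donor of benzylamino does not by itself set the number: compound 3 and compound 4 both lack that donor, yet they stand apart beyond the scatter. Nothing measured here explains these differences.

Benzylamino and phenoxy still differ in more than one way, and two further groups would help to separate those differences: phenylamino, which keeps the nitrogen and its hydrogen but drops the benzyl carbon, and benzyloxy, which keeps that carbon but has oxygen in place of the nitrogen. Going by these compounds, what a chlorine or a methoxy group on the phenyl ring of phenoxy would do to the number also stays open.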